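The compounds below may be only part of what the source reports. "The series", "measured", "known", "first", "only" and "open" are said of these compounds alone.

Among the compounds with values here, in an assay on isolated protein for inhibition of Rho-associated protein kinase 2 (Homo sapiens), read by scintillation counting, radiometric assay and 33P incorporation, with a stated time of 40 min, in the presence of a further agent that is not named here (a higher number here means a weaker inhibitor, a lower number a stronger inhibitor), compound 1 `Cc1ccc(C(=O)Nc2cccc(NC(=O)COc3ccc4c(=O)ccoc4c3)c2)cc1` gives 22 nM, and compound 2 `O=C(COc1ccc2c(=O)ccoc2c1)Nc1cccc(NC(=O)c2ccc(Br)cc2)c1` gives 49 nM, the higher of the two numbers measured so far. Within the data shown here, the single measured step, a 2.2-fold higher number from compound 1 to compound 2 (0.35 log units; beyond the scatter), is a modest change. Compound 3 `Cc1nc(C(=O)Nc2cccc(NC(=O)COc3ccc4c(=O)ccoc4c3)c2)cs1` differs from compound 2 by 2-methyl-1,3-thiazol-4-yl in place of 4-bromophenyl on a carbonyl carbon. Among the measured compounds shown here, no measured step covers a change of this kind, so the expectation rests only on the modest size of the one step seen and on the value of compound 2. Compound 3 is therefore expected at an estimated 60 nM, between 20 nM and 200 nM, an expected step of a 1.2-fold higher number from compound 2 to compound 3 (0.09 log units; within the scatter).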

Compound 3, half-maximal inhibitory concentration: 33 nM
The estimate for compound 3 lay 1.8-fold (0.26 log units) above the measured number; low and high end bracket the measured number.
By their numbers in this assay, from the lowest: compounds 1, 3 and 2 (each within the scatter of the next, the first and the last beyond it).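

The carbonyl carbon accepts a five-membered aromatic ring with 2 hetero atoms as readily as a six-membered ring of carbon only: 2-methyl-1,3-thiazol-4-yl gives both a 1.5-fold lower number from compound 2 to compound 3 (0.17 log units; within the scatter) and a 1.5-fold higher number from compound 1 to compound 3 (0.18 log units; within the scatter) as steps within the scatter. This group therefore stands level with each of the two phenyl groups, even though those two differ from each other beyond the scatter.

On these data alone, how a saturated ring such as piperidine or a simple amine would fare at this place remains open. What lies behind these small steps is also open, as no measurement at hand bears on it.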